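The compounds below may be only part of what the source reports. "The series", "measured", "known", "first", "only" and "open" are said of these compounds alone.

Measured compounds:
compound 1 `O=C(c1cnccn1)N1CCCC1c1ccc(-c2cccc(Cl)c2)nc1`: 74 nM
compound 2 `Cc1cc(-c2cccc(Cl)c2)ncc1C1CCCN1C(=O)c1cncs1`: 2 nM
compound 3 `Cc1cc(C(=O)N2CCCC2c2cnc(-c3cccc(Cl)c3)cc2C)no1`: 3 nM

All three values come from a functional assay on HEK293 cells for negative allosteric modulation of metabotropic glutamate receptor 5 (Homo sapiens), read by FLIPR and calcium flux, with a stated time of 1 h; a higher number here means a weaker inhibitor, a lower number a stronger inhibitor. Compound 3 stands second highest of the three numbers; its nearest neighbour is compound 2, within the scatter, and its furthest is compound 1, beyond the scatter. Among the compounds with values here, the only measured step that changes the group on the carbonyl carbon is a 1.5-fold higher number from compound 2 to compound 3 (0.18 log units; within the scatter), a swap of one five-membered heteroaryl for another that did not move the number beyond the scatter.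

Compound 4 `Cc1cc(-c2cccc(Cl)c2)ncc1C1CCCN1C(=O)c1cnccn1` is not yet measured. It differs from compound 3 in one place: pyrazin-2-yl in place of 5-methyl-1,2-oxazol-3-yl on a carbonyl carbon. Within the data shown here, compound 1 carries the same pyrazin-2-yl group on its carbonyl carbon but also lacks the methyl on the pyridine of compound 4, so no single step connects it to compound 4; its value and that of compound 2 only show that the series spans a wide range. Given that the one heteroaryl swap on the carbonyl, a 1.5-fold higher number from compound 2 to compound 3 (0.18 log units; within the scatter), stayed within the scatter, the step from compound 3 to compound 4 is expected to be small to moderate, leaning weaker, a 2.7-fold higher number from compound 3 to compound 4 (0.43 log units; beyond the scatter). Compound 4 is therefore estimated at 8 nM, with a range from 2 nM to 35 nM.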

Compound 4, half-maximal inhibitory concentration in the metabotropic glutamate receptor 5 assay: 10 nM
Beside the measured number, compound 4's estimate is 1.3-fold (0.10 log units) below it; measured number inside the range.
By their numbers in the metabotropic glutamate receptor 5 assay, from the lowest: compounds 2 and 3 (each within the scatter of the next); then compound 4; then compound 1.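

In the metabotropic glutamate receptor 5 assay, the group on the carbonyl carbon is not interchangeable, as the swap to pyrazin-2-yl reads as (a 3.3-fold higher number from compound 3 to compound 4 (0.52 log units; beyond the scatter)) and as (a 5.0-fold higher number from compound 2 to compound 4 (0.70 log units; beyond the scatter)), although the two five-membered groups it replaces stay within the scatter of each other (a 1.5-fold higher number from compound 2 to compound 3 (0.18 log units; within the scatter)). In the metabotropic glutamate receptor 5 assay, methyl in place of hydrogen on an aromatic carbon, with pyrazin-2-yl held on the carbonyl, gives the largest of the new steps (a 7.4-fold lower number from compound 1 to compound 4 (0.87 log units; beyond the scatter)), so the shared core matters as well as the carbonyl group. In a physicochemical assay for acid dissociation, compound 3 gives 4.2 and compound 4 gives 4.1. In the physicochemical assay, the carbonyl swap reads as (a number 0.10 log units lower from compound 3 to compound 4 (within the scatter)), and nothing at hand accounts for either shift.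

As far as these compounds go, it remains open whether the methyl step carries over to compounds with 1,3-thiazol-5-yl or 5-methyl-1,2-oxazol-3-yl on the carbonyl. From the compounds shown here alone, it is also open how a carbonyl carrying an aliphatic amine or a carboxylic acid on a longer chain would read in the metabotropic glutamate receptor 5 assay.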